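Changing the Aromatic Group on the Ring Nitrogen

The compounds below may be only part of what the source reports. "The series", "measured", "known", "first", "only" and "open" are said of these compounds alone.

Compound 1 `COc1cccc(-n2cc(COc3cccc(NC(=O)Nc4ccc(Cl)c(C(F)(F)F)c4)c3)nn2)c1`: 1310 nM
Compound 2 `Cc1ccc(-n2cc(COc3cccc(NC(=O)Nc4ccc(Cl)c(C(F)(F)F)c4)c3)nn2)cc1`: 5430 nM
Compound 3 `O=C(Nc1cccc(OCc2cn(-c3cccc(Cl)c3)nn2)c1)Nc1ccc(Cl)c(C(F)(F)F)c1`: 2020 nM

These three compounds share one core and differ only in the aromatic group attached to an aromatic nitrogen of the core; all were tested in a functional assay on HepG2 cells (Homo sapiens) for inhibition, read by MTT assay, with a stated time of 72 h; on this read-out higher numbers stand for weaker inhibition and lower numbers for stronger inhibition. Compound 1 gives the lowest number of the three. Its nearest neighbour is reached by a step within the scatter, a 1.5-fold higher number from compound 1 to compound 3 (0.19 log units; within the scatter), while the furthest is a 4.1-fold higher number from compound 1 to compound 2 (0.62 log units; beyond the scatter). The third step, a 2.7-fold lower number from compound 2 to compound 3 (0.43 log units; beyond the scatter), is also modest.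

Compound 4 `O=C(Nc1cccc(OCc2cn(-c3ccccc3Br)nn2)c1)Nc1ccc(Cl)c(C(F)(F)F)c1` has not yet been measured in this assay. Relative to compound 1 it carries 2-bromophenyl in place of 3-methoxyphenyl on an aromatic nitrogen. Going by the values given here, two measured steps bear on this change, since both also swap the aromatic group on that nitrogen: a 4.1-fold higher number from compound 1 to compound 2 (0.62 log units; beyond the scatter) and a 2.7-fold lower number from compound 2 to compound 3 (0.43 log units; beyond the scatter). Among the compounds with values here, both were modest, and none of the measured compounds carries bromine, so nothing here points to a large move. A modest rise from compound 1 seems the most likely outcome, landing between the numbers of compound 1 and compound 2.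

Compound 4 is therefore expected to give about 2500 nM in this assay, with a range from 1000 nM to 7000 nM. This estimate corresponds to an expected step of a 1.9-fold higher number from compound 1 to compound 4 (0.28 log units; within the scatter).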

Compound 4, half-maximal inhibitory concentration: 2810 nM
The estimate for compound 4 lay 1.1-fold (0.05 log units) below the measured number; low and high end bracket the measured number.
By their numbers in this assay, from the lowest: compounds 1, 3, 4 and 2 (each within the scatter of the next, the first and the last beyond it).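

In this assay, a halogen-bearing ring on the aromatic nitrogen now gives a step from compound 1 that lies beyond the scatter, a 2.1-fold higher number from compound 1 to compound 4 (0.33 log units; beyond the scatter), whereas the 3-chlorophenyl group of compound 3 did not. Compound 4 cannot be told apart from either of the other two compounds, with a 1.4-fold higher number from compound 3 to compound 4 (0.14 log units; within the scatter) and a 1.9-fold lower number from compound 2 to compound 4 (0.29 log units; within the scatter) both within the scatter, even though compound 2 and compound 3 differ from each other by more than the scatter. Bromine is new to this set, and replacing the 3-methoxyphenyl group with 2-bromophenyl still produces only a modest step, so all four aromatic groups remain within the span set by compound 1 and compound 2.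

The 2-bromophenyl group differs from the 3-chlorophenyl group in both the halogen and its place on the ring, and the two changes cannot be separated here, while a phenyl ring carrying an amine or a carboxylic acid remains an open case. Nothing in the information shown explains why these four numbers differ.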